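The compounds below may be only part of what the source reports. "The series", "measured", "known", "first", "only" and "open" are said of these compounds alone.

Of the compounds shown here, two have been tested in a functional assay on the whole organism (strain Swiss albino) for inhibition, with Mus musculus as the target, in the formalin test, with a stated time of 30 min, at a dose of 100 mg/kg (on this read-out lower numbers stand for less inhibition and higher numbers for more inhibition at the one dose given (going by the name of the read-out)), so far. Compound 1 `CCN1CCc2c(c(C)nn2C(=O)Nc2ccc(C)cc2C)C1` gives 16.3% in this assay. Compound 2 `CCN1CCc2c(c(C(C)(C)C)nn2C(=O)Nc2cc(C)ccc2C)C1` carries a tert-butyl group on the shared core where compound 1 carries a methyl group, and a differently substituted phenyl ring on the amide nitrogen. In this assay compound 2 gives 15.7%. On the numbers shown, compound 2 stands alongside compound 1, the two values lying within the usual scatter of each other, so no ordering between them can be read off.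

The step from compound 2 to compound 3 `CCN1CCc2c(c(C(C)(C)C)nn2C(=O)Nc2ccc(C)cc2C)C1` changes only the arrangement of atoms on the amide nitrogen: 2,4-dimethylphenyl in place of 2,5-dimethylphenyl on an amide-type nitrogen. Going by the values given here, no measured pair shows this change directly. Both measured compounds sit at a similar low level of inhibition, and compound 1, which already carries the 2,4-dimethylphenyl group, gives 16.3% in this assay. The step from compound 2 to compound 3 is therefore expected to be a number 0.3 percentage points higher from compound 2 to compound 3 (within the scatter), a change that stays within the scatter. Compound 3 is estimated to give 16% in this assay, with a likely range from 7% to 26%.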

Compound 3, a percentage reported as inhibition, in the whole organism at one dose (the size of the read-out at that dose, not a potency): 59.9%
Compound 3: the middle estimate sits 43.9 percentage points below what was measured, outside the stated range (above it).
By their numbers in this assay, from the lowest: compounds 2 and 1 (each within the scatter of the next); then compound 3.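

Compound 3 shows that in this assay the arrangement of the two methyl groups on the phenyl ring can matter greatly: putting 2,4-dimethylphenyl in place of 2,5-dimethylphenyl on the amide-type nitrogen, with no atom gained or lost, gives a number 44.2 percentage points higher from compound 2 to compound 3 (beyond the scatter). The group on the aromatic carbon also counts, as tert-butyl in place of methyl gives a number 43.6 percentage points higher from compound 1 to compound 3 (beyond the scatter). Each of these steps starts from a compound that has only one of the two features of compound 3, so among these three compounds the high number appears only where tert-butyl and 2,4-dimethylphenyl occur together, and neither group is enough alone.

Nothing available here explains why either change has so large an effect. The compounds shown leave open whether a smaller branched group such as isopropyl on the aromatic carbon would keep this level of inhibition, and whether a methoxy group or a chlorine atom could take the place of a methyl group on the phenyl ring.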